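The source may hold more compounds than are shown below. What is called first, only, known or untested is meant among the compounds shown, and "the series" means these compounds.

Going by the values given here, in a functional assay on cells (Neutrophil, Homo sapiens) for inhibition, with a stated time of 10 min (on this read-out higher numbers stand for weaker inhibition and lower numbers for stronger inhibition), only two compounds have numbers so far. Compound 1 (`CCOC(=O)c1cnn(CC(O)CC)c1NC(=O)Nc1cccc2ccccc12`) gives 9.6 nM, the higher of the two numbers. Compound 2 (`CCOC(=O)c1cnn(CC(O)CC)c1NC(=O)Nc1ccccc1F`) gives 0.0016 nM, a far lower number and well beyond the scatter, so compound 1 is the weaker inhibitor of this pair.

Compound 3 (`CCOC(=O)c1cnn(CC(C)O)c1NC(=O)Nc1cccc2ccccc12`) has not yet been measured. It differs from compound 1 in one place: hydrogen in place of methyl on a saturated chain carbon, two bonds along the chain from an oxygen on a saturated carbon. This puts hydrogen in place of methyl on a saturated chain carbon, two bonds along the chain from an oxygen on a saturated carbon, turning 2-hydroxybutyl into 2-hydroxypropyl. Among the compounds with values here, no measured pair shows this change, so the data offer no direct guide. The expectation is therefore no step beyond the scatter and no firm direction, and the expected change is a 1.0-fold higher number from compound 1 to compound 3 (0.02 log units; within the scatter). For compound 3, the estimated value is 10 nM, with an expected range from 2 nM to 50 nM.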

Compound 3, half-maximal inhibitory concentration: 0.00097 nM
Estimate against measurement, compound 3: 10000-fold (4.01 log units) above, and the stated range ends above it.
By their numbers in this assay, from the lowest: compounds 3 and 2 (each within the scatter of the next); then compound 1.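

In this assay, going from the 2-hydroxybutyl group to the 2-hydroxypropyl group gives a 9900-fold lower number from compound 1 to compound 3 (4.00 log units; beyond the scatter), so this change of one carbon is far from neutral. Compound 1 and compound 2 both carry 2-hydroxybutyl and so said nothing about this chain, whereas the new pair shows that inhibition here responds strongly to hydrogen in place of methyl on a saturated chain carbon, two bonds along the chain from an oxygen on a saturated carbon. No measured evidence here accounts for so large a step from so small a change.

Open, as far as these compounds go, is whether a shorter 2-hydroxyethyl chain, a longer 2-hydroxypentyl chain or an amine in place of the hydroxyl would hold this level of inhibition. Also open, from the compounds shown here alone, is whether the same change would have a similar effect in compound 2.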